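Swapping the Aryl Group on a Shared Core

The compounds below may be only part of what the source reports. "The series", "measured", "known", "first", "only" and "open" are said of these compounds alone.

Compound 1 `COC(=O)C1=C(C)N=C(C)/C(=C(\O)OC)C1c1ccccc1OC` is the stronger of the two measured compounds: in a functional assay (muscle tissue) with Cavia porcellus as the target (on this read-out lower numbers stand for an effect already at smaller amounts and higher numbers for an effect only at larger amounts of compound), compound 1 gives 57.5 nM, while compound 2 `COC(=O)C1=C(C)N=C(C)/C(=C(\O)OC)C1c1cccc(OC(C)=O)c1` gives 6030 nM in this assay, a gap well beyond the usual scatter. Compound 3 `COC(=O)C1=C(C)N=C(C)/C(=C(\O)OC)C1c1cccc(I)c1` carries 3-iodophenyl in place of 2-methoxyphenyl on a saturated ring carbon. Among the measured compounds shown here, no measured pair shows this exact change, so the size of the step is uncertain. A modest loss is expected, with the step from compound 1 to compound 3 estimated at a 2.6-fold higher number from compound 1 to compound 3 (0.42 log units; beyond the scatter) in this assay. Compound 3 is therefore expected to give 150 nM, within a range of 30 nM to 800 nM.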

Compound 3, half-maximal effective concentration: 41.7 nM
For compound 3 the middle estimate is 3.6-fold (0.56 log units) above the measured one; measured number inside the range.
By their numbers in this assay, from the lowest: compounds 3 and 1 (each within the scatter of the next); then compound 2.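

Replacing 2-methoxyphenyl with 3-iodophenyl gives a 1.4-fold lower number from compound 1 to compound 3 (0.14 log units; within the scatter), so two differently substituted aryl groups on this saturated ring carbon read the same within the scatter. The group on the aryl ring still matters greatly, as iodo in place of acetoxy gives a 140-fold lower number from compound 2 to compound 3 (2.16 log units; beyond the scatter), the large gap that compound 2 alone could not place. Nothing available explains either result. The compounds shown leave open how an amine or a carboxylic acid in place of the iodo group would fare.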